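Para Substituent Swap on the Sulfonyl Aryl Ring

This account rests on a few compounds, and the source may have more. Where it says the series, first, only, none or still open, it means among the compounds named here.

Compound 3 `O=C1/C(=C/c2ccc(F)cc2)CN(S(=O)(=O)c2ccc(Cl)cc2)C/C1=C\c1ccc(F)cc1` gives 7000 nM in a functional assay on SMMC-7721 cells (Homo sapiens) for cytotoxicity, read by MTT assay, with a stated time of 24 h (on this read-out lower numbers stand for stronger inhibition and higher numbers for weaker inhibition), the second highest of the three numbers recorded; compound 1 `O=C1/C(=C/c2ccc(F)cc2)CN(S(=O)(=O)c2ccc(O[N+](=O)[O-])cc2)C/C1=C\c1ccc(F)cc1` gives 5000 nM and compound 2 `O=C1/C(=C/c2ccc(F)cc2)CN(S(=O)(=O)c2ccc(F)cc2)C/C1=C\c1ccc(F)cc1` gives 14700 nM. Compound 4 `N#Cc1ccc(S(=O)(=O)N2C/C(=C\c3ccc(F)cc3)C(=O)/C(=C/c3ccc(F)cc3)C2)cc1` differs from compound 3 by cyano in place of chloro on an aromatic carbon. The measured steps that bear on this position are a 1.4-fold higher number from compound 1 to compound 3 (0.15 log units; within the scatter) and a 2.1-fold lower number from compound 2 to compound 3 (0.32 log units; beyond the scatter), alongside a 2.9-fold higher number from compound 1 to compound 2 (0.47 log units; beyond the scatter); none of them involves a cyano group, so their guidance is indirect. Because a 1.4-fold higher number from compound 1 to compound 3 (0.15 log units; within the scatter) and a 2.1-fold lower number from compound 2 to compound 3 (0.32 log units; beyond the scatter) are only modest, compound 4 is expected to show a step of about a 1.1-fold higher number from compound 3 to compound 4 (0.06 log units; within the scatter), plausibly within the scatter. The estimate for compound 4 is therefore 8000 nM, with a range from 3000 nM to 20000 nM.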

Compound 4, half-maximal inhibitory concentration: 15000 nM
Compound 4: the middle estimate sits 1.9-fold (0.27 log units) below what was measured; the measured number falls inside the stated range.
By their numbers in this assay, from the lowest: compounds 1 and 3 (each within the scatter of the next); then compounds 2 and 4 (each within the scatter of the next).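

In this assay cyano does not match chloro on this aromatic carbon: a 2.1-fold higher number from compound 3 to compound 4 (0.33 log units; beyond the scatter), whereas a 1.0-fold higher number from compound 2 to compound 4 (0.01 log units; within the scatter), which leaves cyano level with fluoro. With a 3.0-fold higher number from compound 1 to compound 4 (0.48 log units; beyond the scatter), the four compounds fall into two pairs, compounds 1 and 3 at the lower numbers and compounds 2 and 4 at the higher ones. Nothing given here accounts for this split.

As far as these compounds go, whether an amine or a carboxylic acid at this place would join either pair remains open, as does whether the split holds on a core with other benzylidene substituents.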